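Working notes: fluoro for methyl on the sulfonyl aryl

The compounds below may be only part of what the source reports. "The series", "measured", "known", "first", "only" and "open" are said of these compounds alone.

Three compounds of the shared core have numbers in an assay on HEK293 cells for negative allosteric modulation of metabotropic glutamate receptor 5 (Homo sapiens), read by FLIPR; on this read-out lower numbers stand for stronger inhibition and higher numbers for weaker inhibition. Compound 1 `Cc1cccc(-c2noc(C3CN(S(=O)(=O)c4cccc(C)c4)C3)n2)c1` gives 650 nM, compound 2 `O=S(=O)(c1ccc(F)cc1)N1CC(c2nc(-c3cccc(Cl)c3)no2)C1` gives 130 nM, and compound 3 `Cc1ccc(S(=O)(=O)N2CC(c3nc(-c4cccc(C)c4)no3)C2)cc1` gives 670 nM. Compound 3 thus holds the highest number of the three, though the nearest one, compound 1, sits within the scatter: a 1.0-fold higher number from compound 1 to compound 3 (0.01 log units; within the scatter). Compound 2 stands well apart, beyond the scatter, but it differs from compound 3 in two places at once, so its lower number cannot be assigned to either change.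

Compound 4 `Cc1cccc(-c2noc(C3CN(S(=O)(=O)c4ccc(F)cc4)C3)n2)c1` is not yet measured. Its change from compound 3 is fluoro in place of methyl on an aromatic carbon, the same swap that compound 2 carries on its sulfonyl aryl, there combined with a 3-chlorophenyl instead of 3-methylphenyl. Among the measured compounds shown here, no measured step isolates this single change. For the measured compounds named here, the only single-place step, between compound 1 and compound 3, lies within the scatter and concerns the other methyl position. With only compound 2 as an indirect hint, a modest move toward lower numbers is expected for compound 4, a 1.9-fold lower number from compound 3 to compound 4 (0.28 log units; within the scatter), with wide uncertainty. The estimate for compound 4 in this assay is 350 nM, between 120 nM and 900 nM.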

Compound 4, half-maximal inhibitory concentration: 950 nM
Beside the measured number, compound 4's estimate is 2.7-fold (0.43 log units) below it, and the stated range ends below it.
By their numbers in this assay, from the lowest: compound 2; then compounds 1, 3 and 4 (each within the scatter of the next).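

In this assay, the change from 4-methylphenyl to 4-fluorophenyl on the sulfonyl sulfur gives a 1.4-fold higher number from compound 3 to compound 4 (0.15 log units; within the scatter), and the change from 3-methylphenyl gives a 1.5-fold higher number from compound 1 to compound 4 (0.16 log units; within the scatter), so with a 3-methylphenyl on the other side of the shared core, these three sulfonyl aryl groups cannot be told apart. Among the compounds shown here, the step of a 7.3-fold higher number from compound 2 to compound 4 (0.86 log units; beyond the scatter) isolates methyl in place of chloro for the first time and places the separation of compound 2 at that aromatic carbon, not at the fluoro on the sulfonyl aryl. Nothing available explains either result.

On these data alone, whether chloro keeps that advantage with 4-methylphenyl or 3-methylphenyl on the sulfonyl sulfur remains open. Also open, as far as these compounds go, is how a methoxy, a nitrile or an amine on either aryl group would read.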